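Shifting the Pyridine Nitrogen in a Cytotoxic Series

This account rests on a few compounds, and the source may have more. Where it says the series, first, only, none or still open, it means among the compounds named here.

In a functional assay on DU-145 cells (Homo sapiens) for cytotoxicity, read by CCK-8 assay and cell counting, with a stated time of 2 days (on this read-out lower numbers stand for stronger inhibition and higher numbers for weaker inhibition), compound 1 `Oc1ccc(-c2cc(-c3ccncc3)nc(-c3ccc(Cl)cc3)c2)cc1` gives "not determined" (no result reported), so no number is available for it. Two relatives do have one: compound 3 `Oc1cccc(-c2cc(-c3ccncc3)nc(-c3ccc(Cl)cc3)c2)c1` gives 2510 nM in this assay, and compound 2 `Oc1ccc(-c2cc(-c3ccsc3)nc(-c3ccccc3Cl)c2)cc1` gives 3890 nM; these two values lie close together, within the usual spread of repeated measurements. Compound 4 `Oc1ccc(-c2cc(-c3ccc(Cl)cc3)nc(-c3cccnc3)c2)cc1` differs from compound 1 in a single place: pyridin-3-yl in place of pyridin-4-yl on an aromatic carbon. Within the data shown here, no measured pair shows what this change does, so the size and direction of the step in this assay are unknown; a shift no larger than the usual scatter, in either direction, seems the most likely outcome. Taking the two measured relatives as a guide, compound 4 is expected near 3000 nM, with a plausible range from 1000 nM to 9000 nM.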

Compound 4, half-maximal inhibitory concentration: 22800 nM
Compound 4: the middle estimate sits 7.6-fold (0.88 log units) below what was measured; the measured number lies above the stated range.
By their numbers in this assay, from the lowest: compounds 3 and 2 (each within the scatter of the next); then compound 4.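

No step can be read for compound 4, as compound 1, which differs from it in one place, has no number in this assay to compare. What swapping pyridin-4-yl for pyridin-3-yl does therefore stays open, and no evidence here explains the value of compound 4.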